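This account rests on a few compounds, and the source may have more. Where it says the series, first, only, none or still open, it means among the compounds named here.

Measured so far in a functional assay on NCI-H23 cells (Homo sapiens) for cytotoxicity, read by sulforhodamine B assay, with a stated time of 72 h; on this read-out higher numbers stand for weaker inhibition of growth and lower numbers for stronger inhibition of growth:
- compound 1, `CCCCCCCCC(=O)N1c2ccccc2CCC1C(=O)Nc1ccccc1C(F)(F)F`: 4220 nM
- compound 2, `O=C(Nc1ccccc1C(F)(F)F)C1CCc2ccccc2N1C(=O)c1ccccc1Cl`: 2150 nM
- compound 3, `O=C(Nc1ccccc1C(F)(F)F)C1CCc2ccccc2N1`: 56800 nM

Compound 3 stands at the highest number of the three. Its nearest neighbour is compound 1, reached by a 13-fold higher number from compound 1 to compound 3 (1.13 log units; beyond the scatter), and its furthest is compound 2, reached by a 26-fold higher number from compound 2 to compound 3 (1.42 log units; beyond the scatter); both steps are beyond the scatter and both mean weaker inhibition of growth once the nitrogen on the aromatic ring in the ring carries only hydrogen.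

Compound 4, `O=C(Nc1ccccc1C(F)(F)F)C1CCc2ccccc2N1C(=O)c1ccc(Cl)cc1`, is not yet measured. Relative to compound 3 the change is (4-chlorophenyl)carbonyl in place of hydrogen on a nitrogen on an aromatic ring in a ring.

Among the compounds with values here, two measured steps bear on this change directly. Going from compound 2 to compound 3 removes a (2-chlorophenyl)carbonyl from the same nitrogen, and going from compound 1 to compound 3 removes an octylcarbonyl there; both gave large increases. The step from compound 1 to compound 2, a 2.0-fold lower number from compound 1 to compound 2 (0.29 log units; within the scatter), shows that exchanging the octyl for a chlorophenyl on that carbonyl carbon changes little. Compound 4 restores a chlorophenylcarbonyl on that nitrogen, differing from compound 2 only in where the chlorine sits on the ring, so a large drop in the number, close to the reverse of the step from compound 2 to compound 3, is expected.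

For compound 4 the estimated value is 3000 nM, with a likely range of 1200 nM to 8000 nM, that is an expected step of a 19-fold lower number from compound 3 to compound 4 (1.28 log units; beyond the scatter).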

Compound 4, concentration for 50% growth inhibition: 307 nM
Compound 4: middle estimate off by 9.8-fold (0.99 log units), on the high side; the measured number lies below the stated range.
By their numbers in this assay, from the lowest: compound 4; then compounds 2 and 1 (each within the scatter of the next); then compound 3.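

In this assay, the (4-chlorophenyl)carbonyl on the nitrogen gives a 190-fold lower number from compound 3 to compound 4 (2.27 log units; beyond the scatter), so acylation at this nitrogen can deliver more than the octylcarbonyl and (2-chlorophenyl)carbonyl groups suggested. The two chlorophenyl isomers also separate, with a 7.0-fold lower number from compound 2 to compound 4 (0.85 log units; beyond the scatter), so where the chlorine sits on the phenyl ring matters here, a dependence that compounds 1 to 3 could not reveal. The group on the carbonyl carbon is therefore not interchangeable: a 14-fold lower number from compound 1 to compound 4 (1.14 log units; beyond the scatter) lies beyond the scatter, whereas a 2.0-fold lower number from compound 1 to compound 2 (0.29 log units; within the scatter) lies within it, so compound 2 goes against any general advantage of chlorophenyl over octyl.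

No supporting data bear on why the 4-chlorophenyl group outperforms the 2-chlorophenyl group on this read-out. The compounds shown leave open whether the gain is specific to chlorine or extends to other groups at the same place on the phenyl ring, such as bromine, methoxy or a nitrile, and how an unsubstituted phenyl on the carbonyl carbon would compare.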